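This account rests on a few compounds, and the source may have more. Where it says the series, first, only, none or still open, it means among the compounds named here.

In an ADME assay on GES1 cells (Homo sapiens) for inhibition, read by MTT assay, with a stated time of 72 h (on this read-out higher numbers stand for weaker inhibition and lower numbers for stronger inhibition), compound 1 `Cc1cc(Nc2cc(-c3ccccc3)[nH]n2)n2nc(SCc3c(Cl)cccc3Cl)nc2n1` gives 39600 nM and compound 3 `Cc1cc(Nc2cc(-c3ccccc3)[nH]n2)n2nc(SCc3nc4ccccc4[nH]3)nc2n1` gives 27800 nM. Among the compounds with values here, these are the only two exact numbers so far, and they stand within the scatter of each other, as a 1.4-fold lower number from compound 1 to compound 3 (0.15 log units; within the scatter) shows. Compound 2 `C=CCSc1nc2nc(C)cc(Nc3cc(-c4ccccc4)[nH]n3)n2n1` yields only a limit, > 50000 nM. Compound 3 therefore sits level with compound 1 on the numbers shown, and no order can be drawn between them.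

Compound 4 `Cc1cc(Nc2cc(-c3ccccc3)[nH]n2)n2nc(SCc3csc4ccccc34)nc2n1` differs from compound 3 in one place: 1-benzothiophen-3-yl in place of 1H-benzimidazol-2-yl on a saturated chain carbon bound to a sulfur. This puts 1-benzothiophen-3-yl in place of 1H-benzimidazol-2-yl on a saturated chain carbon bound to a sulfur.

All three measured steps bear on this change, since each exchanges the group at that same place. Besides the step already given, they are an at least 1.2-fold higher number from compound 1 to compound 2 (0.10 log units; that floor lies within the scatter) and an at least 1.7-fold lower number from compound 2 to compound 3 (0.25 log units; that floor lies within the scatter). Neither of these two limit-based steps shows a change beyond the scatter, and the exact step between compound 1 and compound 3 stays within it too. In this assay, then, no step beyond the scatter and no firm direction is expected for the new exchange. The expected step is a 1.1-fold higher number from compound 3 to compound 4 (0.03 log units; within the scatter). Compound 4 is estimated at 30000 nM, with an expected range from 14000 nM to 50000 nM.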

Compound 4, half-maximal inhibitory concentration: 29200 nM
Estimate against measurement, compound 4: 1.0-fold (0.01 log units) above; measured number inside the range.
By their numbers in this assay, from the lowest: compounds 3, 4 and 1 (each within the scatter of the next). At a limit, above all of these: compound 2.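

In this assay, 1-benzothiophen-3-yl on the saturated chain carbon bound to a sulfur gives a 1.1-fold higher number from compound 3 to compound 4 (0.02 log units; within the scatter), so a group with no hydrogen-bond donor takes the place of one that carries a donor, and the number stays within the scatter. Set against 2,6-dichlorophenyl at this place, the same group gives a 1.4-fold lower number from compound 1 to compound 4 (0.13 log units; within the scatter), which leaves 1-benzothiophen-3-yl, 1H-benzimidazol-2-yl and 2,6-dichlorophenyl indistinguishable here, whether the aromatic ring holds nitrogen, sulfur or carbon only. Against vinyl only a floor can be read, an at least 1.7-fold lower number from compound 2 to compound 4 (0.23 log units; that floor lies within the scatter), so this exchange does not separate the two groups either, and compound 2 itself stands at a limit and not at a number: the limit of > 50000 nM in this assay, at which 1 of the 4 values shown sits.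

Going by these compounds, what an amine, a carboxylic acid or a longer chain on the saturated chain carbon bound to a sulfur would do to the number stays open, and so does whether any group at this place can move it beyond the scatter. On these data alone, all four compounds also share one core, so how the number answers to a change elsewhere on that core remains unknown.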